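The compounds below may be only part of what the source reports. "The series", "measured", "known", "first", "only" and "open" are said of these compounds alone.

Compound 1 `COc1ccc(Nc2cccc3c2C(=O)N(C2CCC(=O)NC2=O)C3=O)cc1`: 13%
Compound 2 `CCOC(=O)c1ccc(Nc2ccc3c(c2)C(=O)N(C2CCC(=O)NC2=O)C3=O)cc1`: 5%

In an assay on FRT-Jurkat cells for inhibition of nuclear factor NF-kappa-B complex (Homo sapiens), read by flow cytometry, with a stated time of 24 h, tested at 10 uM (on this read-out higher numbers stand for more inhibition at the one concentration tested (going by the name of the read-out) and lower numbers for less inhibition), compound 1 gives 13%, while compound 2 gives 5%. The two numbers lie within the usual scatter of each other, so neither can be set above the other.

Compound 3 `CCc1ccc(Nc2cccc3c2C(=O)N(C2CCC(=O)NC2=O)C3=O)cc1` has not yet been measured. It differs from compound 1 in one place: ethyl in place of methoxy on an aromatic carbon. Going by the values given here, no measured pair shows what this change does here. Compound 3 is therefore expected to give about 13%, within a range from 0% to 30%. The expected step of no change at the digits printed from compound 1 to compound 3 (within the scatter) is estimated to stay within the scatter, with no clear direction.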

Compound 3, a percentage reported as inhibition, at one concentration (the size of the read-out at that concentration, not a potency): 17%
Beside the measured number, compound 3's estimate is 4 percentage points below it, within the range that was stated.
By their numbers in this assay, from the lowest: compounds 2, 1 and 3 (each within the scatter of the next, the first and the last beyond it).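

In this assay, going by these compounds alone, ethyl in place of methoxy on an aromatic carbon, para to a large group, gives a number 4 percentage points higher from compound 1 to compound 3 (within the scatter) and this is the first comparison here of compounds that differ in one place. At this position, compound 1 and compound 3 cannot be told apart, so the oxygen of the methoxy group is not shown to matter for this read-out. Nothing available here explains the result. On these data alone, whether an amine, a carboxylic acid or a longer chain at this position would give a different number remains open.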